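Capping a Hydroxyl: From Compound 1 to Compound 3

The compounds below may be only part of what the source reports. "The series", "measured", "known", "first", "only" and "open" are said of these compounds alone.

Measured compounds:
- compound 1, `O=C(O)COc1ccc(Cl)cc1C#Cc1ccc(CO)cc1F`: 28 nM
- compound 2, `Cc1ccc(S(=O)(=O)N2CCN(C)CC2)cc1C#Cc1cc(Cl)ccc1OCC(=O)O`: 21 nM

Both compounds were tested in an assay on CHO cells for displacement of a labelled ligand from prostaglandin D2 receptor 2 (Homo sapiens), read by scintillation counting; on this read-out higher numbers stand for weaker inhibition and lower numbers for stronger inhibition. Compound 1 gives 28 nM, the higher of the two numbers, while compound 2 gives 21 nM; the gap between them lies within the usual scatter of repeated measurements, so the two compounds cannot be told apart on these data.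

Compound 3, `COCc1ccc(C#Cc2cc(Cl)ccc2OCC(=O)O)c(F)c1`, has not yet been measured. It differs from compound 1 in one place: methyl in place of hydrogen on an oxygen on a saturated carbon. In words, a methyl takes the place of a hydrogen on an oxygen on a saturated carbon, so the hydroxymethyl of compound 1 becomes a methoxymethyl.

Within the data shown here, no measured pair in this set shows what such a change does, so the expectation rests on the two values alone. A step of modest size in this assay is expected, leaning toward a slightly higher number, though a result within the scatter would not surprise. For compound 3 the estimate is 40 nM, with a range from 15 nM to 110 nM, which means an expected step of a 1.4-fold higher number from compound 1 to compound 3 (0.15 log units; within the scatter).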

Compound 3, inhibition constant: 22 nM
Compound 3: middle estimate off by 1.8-fold (0.26 log units), on the high side; the measured number falls inside the stated range.
By their numbers in this assay, from the lowest: compounds 2, 3 and 1 (each within the scatter of the next).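

In this assay, turning the hydroxymethyl into a methoxymethyl gives a 1.3-fold lower number from compound 1 to compound 3 (0.10 log units; within the scatter) and so leaves the two compounds indistinguishable. Among these compounds, this is the only pair here that differs in one place, and it shows that at this position a methyl can take the place of the hydrogen on the oxygen with no change the measurement can detect, so that hydrogen is not needed to keep the number in this range. Nothing available here explains this result.

Still open, going by these compounds, is whether a longer chain on this oxygen, such as an ethyl or a propyl, would leave the number equally undisturbed. It is also unknown what an amine or a carboxylic acid would do in place of the hydroxy, and one pair cannot show whether the same swap behaves alike on a different core.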